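A Methyl Added to the Core: Cytotoxicity Outlook

This account rests on a few compounds, and the source may have more. Where it says the series, first, only, none or still open, it means among the compounds named here.

Of the compounds shown here, three from one set have been tested in an ADME assay on MT4 cells (Homo sapiens) for cytotoxicity, read by MTT assay; on this read-out lower numbers stand for higher toxicity in this test and higher numbers for lower toxicity in this test. Compound 1 `CC(C)Sc1nc(Cc2c(F)cccc2F)cc(=O)[nH]1` reaches only a limit of the assay, > 84000 nM. Compound 2 `Cc1c(Cc2c(F)cccc2F)nc(SC(C)C)[nH]c1=O` likewise stops at a limit, > 77000 nM. Compound 3 `O=C(CSc1nc(Cc2c(Cl)cccc2Cl)cc(=O)[nH]1)c1ccccc1` also gives only a limit, > 12000 nM. The change from compound 1 to compound 2 is methyl in place of hydrogen on an aromatic carbon, and the step that the two limits leave unreadable from compound 1 to compound 2 cannot be read because the limit of > 84000 nM in this assay, at which 1 of the 3 values shown sits, and the limit of > 77000 nM in this assay, at which 1 of the 3 values shown sits, show both ends as limits. How the core of compound 3 differs from that of compound 1 is not broken down here. Compound 4 `Cc1c(Cc2c(Cl)cccc2Cl)nc(SCC(=O)c2ccccc2)[nH]c1=O` carries the same kind of change, (methyl in place of hydrogen on an aromatic carbon), though here the place is ortho to a 2,6-dichlorobenzyl group and para to a large group, whereas in compound 2 it is ortho to a group of 9 heavy atoms and para to an isopropylsulfanyl group. Because the limit of > 12000 nM in this assay, at which 1 of the 3 values shown sits, places compound 3 at a limit, only a limit is expected for compound 4 in this assay too. The step that the limit leaves unreadable from compound 3 to compound 4 is therefore expected to be small. Compound 4 is estimated at 30000 nM in this assay, between 12000 nM and 100000 nM.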

Compound 4, half-maximal cytotoxic concentration: > 60000 nM
Compound 4: a limit, no number; the forecaster's own chance of this, stated with the estimate: 70%; at least 2.0-fold (0.30 log units) between middle value and limit.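

Compound 3 and compound 4 both stop at a limit in this assay rather than giving a number, and the step from one to the other, methyl in place of hydrogen, cannot be read. The compounds shown leave open whether this methyl shifts the cytotoxicity read-out at all, either between compound 1 and compound 2 or between compound 3 and compound 4.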